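Pentan-3-yl in place of isobutyl on the shared core

The source may report more compounds than this note shows. Statements on the series, on what has been measured and on what is new or still open speak of the compounds shown alone.

In an ADME assay for permeability, using PAMPA, with a stated time of 30 min, at pH 7.4 (a lower number here means that the compound crosses the layer more slowly, a higher number that the compound crosses the layer faster), compound 3 `COc1cccc(CNCCCNc2ccnc3cc(CC(C)C)ccc23)c1O` gives 23 10^-6 cm/s on the scale, level with compound 2 `COc1cccc(CNCCCNc2ccnc3cc(CCC(C)C)ccc23)c1O` at 23 10^-6 cm/s on the same scale. Together they form the lowest pair of the three measured compounds, and compound 1 `COc1cccc(CNCCCNc2ccnc3cc(-c4ccc(C(C)(C)C)cc4)ccc23)c1O` stands well apart at 237 10^-6 cm/s in this series. The next structure is compound 4 `CCC(CC)c1ccc2c(NCCCNCc3cccc(OC)c3O)ccnc2c1`, reached from compound 3 by pentan-3-yl in place of isobutyl on an aromatic carbon is the whole difference. Two large steps are on record, a 10-fold lower number from compound 1 to compound 2 (1.01 log units; beyond the scatter) and a 10-fold lower number from compound 1 to compound 3 (1.01 log units; beyond the scatter) as well, but both start from 4-(tert-butyl)phenyl, which plays no part in this change. The closer guide is the exchange between two alkyl groups, no change at the digits printed from compound 2 to compound 3 (within the scatter) and thus within the scatter. No step beyond the scatter is therefore expected in this assay for this change. The expected step is a 1.1-fold higher number from compound 3 to compound 4 (0.05 log units; within the scatter) on this reasoning. For compound 4 the estimated value is 26 10^-6 cm/s with an expected range from 11 10^-6 cm/s to 60 10^-6 cm/s in this assay.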

Compound 4, apparent permeability: 23 10^-6 cm/s
Beside the measured number, compound 4's estimate is 1.1-fold (0.05 log units) above it, within the range that was stated.
By their numbers in this assay, from the lowest: compounds 2, 3 and 4 (each within the scatter of the next); then compound 1.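

In this assay, pentan-3-yl on this aromatic carbon reads the same as the smaller alkyl groups, with no change at the digits printed from compound 3 to compound 4 (within the scatter) and no change at the digits printed from compound 2 to compound 4 (within the scatter). Isobutyl, isopentyl and pentan-3-yl now form a group of three alkyl compounds with no separation among them, so the different branching and carbon count of these groups do not show up in this read-out, whereas a 10-fold lower number from compound 1 to compound 4 (1.01 log units; beyond the scatter) confirms that 4-(tert-butyl)phenyl alone stands apart. Nothing at hand gives a reason for either the alkyl plateau or the gap to compound 1.

As far as these compounds go, it remains open whether the gap belongs to the aromatic ring itself or to the tert-butyl group on it, which an unsubstituted phenyl at this position would address. From the compounds shown here alone, how an amine or a carboxylic acid on this carbon would read against the alkyl compounds also remains open.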